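This account rests on a few compounds, and the source may have more. Where it says the series, first, only, none or still open, it means among the compounds named here.

The measured compounds:

Compound 1 `COc1cc(C)cc(-c2c(-c3ccnc(-c4ccc(C(C)=O)cc4)c3)cnn2CC#N)c1`: in a functional assay on SF-539 cells (Homo sapiens) for inhibition, read by sulforhodamine B assay, with a stated time of 48 h (a lower number here means that less compound is tolerated, a higher number that more compound is tolerated), compound 1 gives > 100000 nM, which is a limit of the assay and not a number.

Compound 2 `Cc1cc(O)cc(-c2nn(CC#N)cc2-c2ccnc(-c3ccc(N(C)C)cc3)c2)c1`: in this assay compound 2 gives 27300 nM.

Compound 1 therefore stands only at a limit, namely (the limit of > 100000 nM in this assay, at which 1 of the 2 values shown sits), and no number for it is known. Among the compounds with values here, compound 2 also carries a dimethylamino group and does give a number; it differs from compound 1 in more than one place, so the two values show no single step. Compound 3 `COc1cc(C)cc(-c2c(-c3ccnc(-c4ccc(N(C)C)cc4)c3)cnn2CC#N)c1` has not yet been measured in this assay. The change from compound 1 to compound 3 is dimethylamino in place of acetyl on an aromatic carbon, para to a large group. In this assay the expected step is an at least 3.3-fold lower number from compound 1 to compound 3 (0.52 log units; beyond the scatter), towards less compound tolerated. This expectation rests on compound 2, which with its dimethylamino group gives 27300 nM. Compound 3 is accordingly estimated at 30000 nM, with a range from 8000 nM to 100000 nM.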

Compound 3, concentration lethal to 50% of the cells: > 100000 nM
Compound 3: no number, only a limit; the forecaster's own chance of this, stated with the estimate: 25%; at least 3.3-fold (0.52 log units) between middle value and limit.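

Compound 3, like compound 1, gives only a limit of the assay and not a number, so no step between compound 1 and compound 3 can be read: the limit of > 100000 nM in this assay, at which 2 of the 3 values shown sit.

The compounds shown leave open whether dimethylamino in place of acetyl on an aromatic carbon changes the read-out at all.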